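Aryl amine variation on the shared core: compound 4

This account rests on a few compounds, and the source may have more. Where it says the series, first, only, none or still open, it means among the compounds named here.

Three compounds share one core and differ only in the group on a nitrogen on an aromatic ring. Compound 1 `CC(C)CCn1cnc2c(NCc3cccc(Cl)c3)nc(N[C@H]3CC[C@H](N)CC3)nc21` carries 3-chlorobenzyl; in a functional assay on EOL1 cells (Homo sapiens) for inhibition, read by fluorescence, with a stated time of 72 h (a lower number here means a stronger inhibitor of growth, a higher number a weaker inhibitor of growth), compound 1 gives 1330 nM. Compound 2 `CC(C)CCn1cnc2c(Nc3ccccc3)nc(N[C@H]3CC[C@H](N)CC3)nc21` carries phenyl, and in this assay compound 2 gives 10 nM. Compound 3 `CC(C)CCn1cnc2c(Nc3cccc(Cl)c3)nc(N[C@H]3CC[C@H](N)CC3)nc21` carries 3-chlorophenyl, and in this assay compound 3 gives 60 nM, the second highest of the three numbers: a 6.0-fold higher number from compound 2 to compound 3 (0.78 log units; beyond the scatter), while a 22-fold lower number from compound 1 to compound 3 (1.35 log units; beyond the scatter).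

The next step is 4-hydroxyphenyl in place of 3-chlorophenyl on a nitrogen on an aromatic ring, giving compound 4 `CC(C)CCn1cnc2c(Nc3ccc(O)cc3)nc(N[C@H]3CC[C@H](N)CC3)nc21`. Going by the values given here, the only measured step that bears on it is the chloro-for-hydrogen change between compound 2 and compound 3, a modest rise; compound 4 undoes that chloro and adds a hydroxy, for which no measured step exists. The loss of chloro alone would be expected to return the number toward that of compound 2, so a modest fall from compound 3 is expected, a 3.0-fold lower number from compound 3 to compound 4 (0.48 log units; beyond the scatter). Compound 4 is therefore expected to give 20 nM in this assay, within 5 nM to 80 nM.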

Compound 4, concentration for 50% growth inhibition: 30 nM
Compound 4: middle estimate off by 1.5-fold (0.18 log units), on the low side; low and high end bracket the measured number.
By their numbers in this assay, from the lowest: compound 2; then compounds 4 and 3 (each within the scatter of the next); then compound 1.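

In this assay, 4-hydroxyphenyl in place of 3-chlorophenyl gives a 2.0-fold lower number from compound 3 to compound 4 (0.30 log units; within the scatter), which lies within the scatter, so the two substituted phenyl groups cannot be told apart at this nitrogen. Against unsubstituted phenyl, hydroxy in place of hydrogen gives a 3.0-fold higher number from compound 2 to compound 4 (0.48 log units; beyond the scatter), beyond the scatter, so compound 4 joins compound 3 in giving a higher number than compound 2, and both substituents tested on the phenyl ring go the same way. The large gap to the benzyl compound also holds for this new group, with a 44-fold lower number from compound 1 to compound 4 (1.65 log units; beyond the scatter) for 4-hydroxyphenyl in place of 3-chlorobenzyl.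

Going by these compounds, compounds 3 and 4 differ in both the substituent and its place on the ring, so the effect of each alone stays open, as does the outcome with 3-hydroxyphenyl, 4-chlorophenyl, 4-methoxyphenyl or 4-aminophenyl at this nitrogen. No evidence on what lies behind these steps is at hand.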